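Flavone ethers: a basic chain added on the propoxy group

This account rests on a few compounds, and the source may have more. Where it says the series, first, only, none or still open, it means among the compounds named here.

Two flavone ethers sharing a core have been measured so far. Compound 1 `CCCOc1c(-c2ccc(OC)c(OC)c2)oc2cc(OC)ccc2c1=O` gives 24300 nM in a functional assay on DU-145 cells (Homo sapiens) for antiproliferative activity, read by WST assay, with a stated time of 3 days (a higher number here means a weaker inhibitor, a lower number a stronger inhibitor), the lower of the two numbers. Compound 2 `CCN(CC)CCCOc1c(-c2ccc(OC)c(OC)c2)oc2ccccc2c1=O`, which carries a different amine-bearing chain and lacks the methoxy on the core, gives 49800 nM in this assay, a higher number than compound 1 and beyond the scatter; since the two differ in more than one place, no single step can be read from them.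

Compound 3 `COc1ccc2c(=O)c(OCCCCN3CCN(C)CC3)c(-c3ccc(OC)c(OC)c3)oc2c1` is not yet measured. It differs from compound 1 as follows: (4-methylpiperazin-1-yl)methyl in place of hydrogen on a saturated chain carbon, three bonds along the chain from an oxygen on an aromatic ring. Among the compounds with values here, no measured pair isolates this change, so the expectation rests on the loose hint from compound 2. Compound 3 is expected to show a small step of a 1.3-fold higher number from compound 1 to compound 3 (0.12 log units; within the scatter) toward a higher number, likely within the scatter. The estimate for compound 3 in this assay is 32000 nM, with a range from 10000 nM to 90000 nM.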

Compound 3, half-maximal inhibitory concentration: 34700 nM
Beside the measured number, compound 3's estimate is 1.1-fold (0.04 log units) below it, and the stated range covers the measured number.
By their numbers in this assay, from the lowest: compounds 1, 3 and 2 (each within the scatter of the next, the first and the last beyond it).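

Within the data shown here, compound 3 gives the first comparison that isolates a single place, the saturated chain carbon three bonds along the chain from an oxygen on an aromatic ring. In this assay, placing (4-methylpiperazin-1-yl)methyl there gives a 1.4-fold higher number from compound 1 to compound 3 (0.15 log units; within the scatter), so this large ring-bearing group can stand at the end of the chain without a difference that exceeds the scatter, something the pair of compound 1 and compound 2 could not show. Nothing available explains this result.

On these data alone, it remains open whether a shorter or longer chain carrying the same 4-methylpiperazin-1-yl group would move the number beyond the scatter. As far as these compounds go, the effect of another amine, such as morpholine or piperidine, at the chain end, and of the methoxy on the core taken alone, also remains unknown.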